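Compound 3 Against a Two-Compound Limit

The source may hold more compounds than are shown below. What is called first, only, known or untested is meant among the compounds shown, and "the series" means these compounds.

Measured so far:
- Compound 1 `COC(=O)CC/C(C)=C/Cc1c(OC)c(C)c2c(c1OCC#CCN1CCN(C(c3ccc(F)cc3)c3ccc(F)cc3)CC1)C(=O)OC2`: > 50000 nM, a limit
- Compound 2 `COC(=O)CC/C(C)=C/Cc1c(OC)c(C)c2c(c1OCC#CCN1CCN(c3ccccc3F)CC1)C(=O)OC2`: > 50000 nM, a limit

In a functional assay on HT-29 cells (Homo sapiens) for inhibition, read by sulforhodamine B assay (a lower number here means a stronger inhibitor, a higher number a weaker inhibitor), compound 2 gives > 50000 nM, which is a limit of the assay and not a number. For the measured compounds named here, neither measured compound has a numerical value, and the only shared reading is the limit of > 50000 nM in this assay, at which 2 of the 2 values shown sit.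

Compound 3 `COC(=O)CC/C(C)=C/Cc1c(OC)c(C)c2c(c1OCC#CCN1CCN(Cc3ccc(Cl)cc3)CC1)C(=O)OC2` has not yet been measured. It carries 4-chlorobenzyl in place of 2-fluorophenyl on an amine nitrogen in a ring.

Going by the values given here, with no measured step to guide the expectation, it rests on the limit of > 50000 nM in this assay, at which 2 of the 2 values shown sit, alone. In this assay the expected change is a number no higher from compound 2 to compound 3 (the limit leaves the size open), with no size beyond the scatter and no clear direction. A report of only a limit is also the likeliest outcome. Compound 3 is estimated at 50000 nM, with an expected range of 20000 nM to 80000 nM.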

Compound 3, half-maximal inhibitory concentration: > 50000 nM
Compound 3 was reported as a limit (the forecaster's own chance of this, stated with the estimate: 75%); the middle value sits exactly at the limit.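

For the compounds shown here, compound 2 and compound 3 are both reported only as limits, so no step between them can be read in this assay. The compounds shown leave open how strongly each inhibits, and whether 4-chlorobenzyl in place of 2-fluorophenyl changes that at all.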